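A Hydroxypropyl Side Chain Enters a Weak Series

The source may hold more compounds than are shown below. What is called first, only, known or untested is meant among the compounds shown, and "the series" means these compounds.

Compound 2 `CCn1c(CNc2ccccc2)nnc1SCc1nc2cc(C)ccc2o1` is measured in an assay on isolated protein for inhibition of long-chain fatty acid transport protein 1 (Homo sapiens); on this read-out lower numbers stand for stronger inhibition and higher numbers for weaker inhibition. In this assay compound 2 gives > 1000 nM, which is a limit of the assay and not a number. Compound 1 `CCc1ccc2oc(CSc3nnc(CNc4ccccc4)n3CC)nc2c1` stands in the same way: in this assay compound 1 gives > 1000 nM, also a limit. The measured step that the two limits leave unreadable from compound 1 to compound 2 cannot be read, since (the limit of > 1000 nM in this assay, at which 2 of the 2 values shown sit). Compound 3 `CCC(O)c1ccc2oc(CSc3nnc(CNc4ccccc4)n3CC)nc2c1` carries 1-hydroxypropyl in place of methyl on an aromatic carbon. For the measured compounds named here, no measured step bears on this exchange, and the only measured step in the set is itself unreadable, so the starting point offers no number to move from. Compound 3 is expected to remain around the same limit, with a step that the limit leaves unreadable from compound 2 to compound 3 estimated as little more than a placeholder. In this assay compound 3 is therefore estimated at 3000 nM, within a range of 700 nM to 20000 nM.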

Compound 3, half-maximal inhibitory concentration: > 1000 nM
Compound 3: a limit, no number; the forecaster's own chance of this, stated with the estimate: 75%; the middle value does not contradict the limit.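

In this assay compound 3 gives > 1000 nM as a limit and not a number. Its steps from compound 1 and compound 2 therefore cannot be read: the limit of > 1000 nM in this assay, at which 3 of the 3 values shown sit. The compounds shown leave open whether any group at this aromatic carbon gives a readable value.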